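Amide methylation and a benzyl swap on the shared core

This account rests on a few compounds, and the source may have more. Where it says the series, first, only, none or still open, it means among the compounds named here.

Compound 3, `COc1cccc(CNC(=O)c2nn(-c3ccc(F)cc3)c(OC[C@@H](O)C[C@@H](O)CC(=O)O)c2C(C)C)c1`, stands second highest of the three numbers in an assay on microsomes from liver for inhibition of 3-hydroxy-3-methylglutaryl-coenzyme A reductase (Rattus norvegicus) (on this read-out lower numbers stand for stronger inhibition and higher numbers for weaker inhibition), where compound 3 gives 16 nM; its nearest neighbour is compound 1, `CC(C)c1c(C(=O)NCC2CCCCC2)nn(-c2ccc(F)cc2)c1OC[C@@H](O)C[C@@H](O)CC(=O)O`, which in this assay gives 17 nM, and the furthest is compound 2, `Cc1ccc(CNC(=O)c2nn(-c3ccc(F)cc3)c(OC[C@@H](O)C[C@@H](O)CC(=O)O)c2C(C)C)cc1`, which gives 15 nM. All three sit within the scatter of one another: a 1.1-fold lower number from compound 1 to compound 2 (0.05 log units; within the scatter), a 1.1-fold lower number from compound 1 to compound 3 (0.03 log units; within the scatter) and a 1.1-fold higher number from compound 2 to compound 3 (0.03 log units; within the scatter) are each small. Compound 4, `Cc1cccc(CN(C)C(=O)c2nn(-c3ccc(F)cc3)c(OC[C@@H](O)C[C@@H](O)CC(=O)O)c2C(C)C)c1`, differs from compound 3 in that (methyl(3-methylbenzyl)amino in place of (3-methoxybenzyl)amino on a carbonyl carbon). The measured steps bear only on the aryl part of this change, and they show that swapping cyclohexyl, 4-methylphenyl and 3-methoxyphenyl on the saturated chain carbon bound to the amide-type nitrogen leaves the number essentially unchanged. Among the measured compounds shown here, no measured step covers the added methyl on the amide-type nitrogen, which removes the one hydrogen-bond donor. The aryl part is therefore expected to be neutral, while the nitrogen methylation carries open uncertainty; a modest rise in number is estimated, a 2.2-fold higher number from compound 3 to compound 4 (0.34 log units; beyond the scatter). Compound 4 is estimated at 35 nM, with a range from 10 nM to 150 nM.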

Compound 4, half-maximal inhibitory concentration: 37 nM
Compound 4: the middle estimate sits 1.1-fold (0.02 log units) below what was measured; low and high end bracket the measured number.
By their numbers in this assay, from the lowest: compounds 2, 3 and 1 (each within the scatter of the next); then compound 4.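

In this assay, among the compounds shown here, methyl(3-methylbenzyl)amino on the carbonyl carbon is the first change to move the number beyond the scatter, and it does so from each of the other compounds by a modest step (a 2.3-fold higher number from compound 3 to compound 4 (0.36 log units; beyond the scatter)) (a 2.5-fold higher number from compound 2 to compound 4 (0.39 log units; beyond the scatter)) (a 2.2-fold higher number from compound 1 to compound 4 (0.34 log units; beyond the scatter)). The earlier swaps among the amino groups had shown no response at this position, whereas this change shows that the position is not indifferent to every change, with the entering group counting 0 hydrogen-bond donors against 1 in (3-methoxybenzyl)amino. No measurement shown here explains the rise.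

The compounds shown do not separate the added methyl on the nitrogen from the change of aryl group, as both arrive together in compound 4. Also open, as far as these compounds go, is how an ethyl group on that nitrogen would read in this assay.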